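A few compounds are considered here, and "the series" means these few. Any claim that something is new, unique, unknown or untested is made for them only; others in the source may bear on it.

Measured so far in a functional assay on MCF7 cells (Homo sapiens) for cytotoxicity, read by sulforhodamine B assay; a higher number here means a weaker inhibitor of growth, a lower number a stronger inhibitor of growth:
compound 1 `CC1=CC[C@@H]([C@@](C)(O)CCCC(C)(C)NC(=S)N/N=C\c2ccc(C)cc2)CC1` — 7230 nM
compound 2 `CC1=CC[C@@H]([C@@](C)(O)CCCC(C)(C)NC(=S)N/N=C\c2ccc(O)cc2)CC1` — 6230 nM

Compound 2 stands with only compound 1 beside it, the two separated by a step within the scatter, namely a 1.2-fold lower number from compound 1 to compound 2 (0.06 log units; within the scatter). Compound 3 `CC1=CC[C@@H]([C@@](C)(O)CCCC(C)(C)NC(=S)N/N=C(/C)c2ccccc2)CC1` differs from compound 2 by a group of 9 heavy atoms (8 carbon, 1 nitrogen; one six-membered aromatic ring of carbon only) in place of a group of 9 heavy atoms (7 carbon, 1 nitrogen, 1 oxygen; one six-membered aromatic ring of carbon only), on an amide-type nitrogen. Among the compounds with values here, the one measured step concerns only the substituent on the aromatic ring and lies within the scatter; no measured step touches the exchange at the amide-type nitrogen, so the direction is open and no move beyond the scatter is expected, the estimated step being a 1.1-fold higher number from compound 2 to compound 3 (0.05 log units; within the scatter). Compound 3 is estimated at 7000 nM, within 2500 nM to 20000 nM.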

Compound 3, concentration for 50% growth inhibition: 23600 nM
Estimate against measurement, compound 3: 3.4-fold (0.53 log units) below; the measured number lies above the stated range.
By their numbers in this assay, from the lowest: compounds 2 and 1 (each within the scatter of the next); then compound 3.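

In this assay, within the data shown here, the group on the amide-type nitrogen is the first place where an exchange moves the number beyond the scatter: a 3.8-fold higher number from compound 2 to compound 3 (0.58 log units; beyond the scatter) and a 3.3-fold higher number from compound 1 to compound 3 (0.51 log units; beyond the scatter). Both steps point to weaker growth inhibition, whereas hydroxy in place of methyl on an aromatic carbon did not separate compound 1 from compound 2. No evidence on hand accounts for this shift. The compounds shown do not tell which part of the entering group carries the change. Going by these compounds, an amine or a carboxylic acid on an aromatic carbon of that group remains open.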